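The source may hold more compounds than are shown below. What is called first, only, known or untested is meant among the compounds shown, and "the series" means these compounds.

In a functional assay on NUGC-3 cells (Homo sapiens) for cytotoxicity, read by sulforhodamine B assay, with a stated time of 72 h (on this read-out lower numbers stand for stronger inhibition of growth and higher numbers for weaker inhibition of growth), three related compounds have been measured. Compound 1 `O=C(Nc1cc(C(F)(F)F)cc(C(F)(F)F)c1)C1CCc2ccccc2N1C(=O)c1ccccc1Cl` gives 1930 nM. Compound 2 `O=C(Nc1ccccc1O)C1CCc2ccccc2N1C(=O)c1ccccc1Cl` gives 36800 nM. Compound 3 `CCCCCCCCC(=O)N1c2ccccc2CCC1C(=O)Nc1ccccc1C(F)(F)F` gives 6180 nM, which places it second highest of the three numbers: compound 1 sits at a lower number than compound 3, and compound 2 at a higher one, and both of these gaps are beyond the usual scatter of repeated measurements. Compound 1 and compound 2 differ from compound 3 in more than one place, so neither gap can be read as the effect of a single change.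

Compound 4 `CCC(=O)N1c2ccccc2CCC1C(=O)Nc1ccccc1C(F)(F)F` has not yet been measured. It differs from compound 3 in one place: hydrogen in place of hexyl on a saturated chain carbon, two bonds along the chain from a carbonyl carbon. Seen one bond further out, the long chain on the amide carbonyl of compound 3 is cut back to a short propanoyl group in compound 4. No pair of measured compounds shows a change of this kind in this assay, so there is nothing here to say how far the number should move. A modest rise in the number, or no change beyond the scatter, is the expectation, giving a step from compound 3 to compound 4 of a 1.5-fold higher number from compound 3 to compound 4 (0.16 log units; within the scatter). For compound 4 the estimated value in this assay is 9000 nM, with a likely range from 3000 nM to 30000 nM.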

Compound 4, concentration for 50% growth inhibition: > 80000 nM
Compound 4: no number, only a limit (the forecaster's own chance of this, stated with the estimate: 5%); middle value at least 8.8-fold (0.94 log units) away from the limit.
By their numbers in this assay, from the lowest: compound 1; then compound 3; then compound 2. At a limit, above all of these: compound 4.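

Among these compounds, this is the first step in the set that changes one place only, and it shows that the group on the saturated chain carbon, two bonds along the chain from a carbonyl carbon, matters greatly: hydrogen in place of hexyl gives an at least 12-fold higher number from compound 3 to compound 4 (1.11 log units; beyond the scatter). In this assay compound 4 gives > 80000 nM, which is a limit of the assay and not a number, so the step has a known lower bound but no known full size. Compound 4 is the only compound shown that reaches this limit, so in this pair the long octylcarbonyl chain goes with measurable growth inhibition and the short propanoyl group does not: the limit of > 80000 nM in this assay, at which 1 of the 4 values shown sits.

What the compounds shown leave open is where between these two lengths the number begins to climb, as a butanoyl or hexanoyl chain would show, and whether a longer chain such as decanoyl would bring the number down further. They also leave open whether length alone counts or whether a chain ending in an amine or a carboxylic acid would serve as well, and they give no reason for the step.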